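Chloro to Fluoro: A Small Halogen Swap

The source may report more compounds than this note shows. Statements on the series, on what has been measured and on what is new or still open speak of the compounds shown alone.

Of the compounds shown here, three sharing one core have been tested in an assay for inhibition of Tryptophan 2,3-dioxygenase (Homo sapiens), with a stated time of 1 h, tested at 10 uM; a lower number here means less inhibition, a higher number more inhibition at the concentration tested (going by the name of the read-out). Compound 1, `Oc1ccc(CNc2cc(Br)cc3[nH]ncc23)cc1O`, was reported as "not active" (no number reported), without a number. Compound 2, `Nc1cc(CNc2cc(Br)cc3[nH]ncc23)ccc1O`, was likewise reported as "not active" (no number reported). Compound 3, `Oc1ccc(CNc2cc(Br)cc3[nH]ncc23)cc1Cl`, is the only one of the three for which a number was recorded: in this assay compound 3 gives 19%. Among the compounds with values here, compound 3 therefore stands as the sole reference point; the other two entries carry no figure that could be set against it, and no step between measured compounds can be read from them.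

Compound 4, `Oc1ccc(CNc2cc(Br)cc3[nH]ncc23)cc1F`, differs from compound 3 in one place: fluoro in place of chloro on an aromatic carbon. Within the data shown here, no measured pair showing this kind of change is available, so the expectation rests on compound 3 alone. Exchanging one halogen for another is expected to move the inhibition little, either in no direction beyond the usual scatter or slightly downward; the expected step from compound 3 to compound 4 is a number 7 percentage points lower from compound 3 to compound 4 (within the scatter). Compound 4 is thus expected to give about 12% in this assay, with a range from 0% to 30%, and a fair chance that it is reported only as not active with no number.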

Compound 4, a percentage reported as inhibition, at one concentration (the size of the read-out at that concentration, not a potency): 26%
Beside the measured number, compound 4's estimate is 14 percentage points below it; low and high end bracket the measured number.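

Fluoro in place of chloro on this aromatic carbon, ortho to a hydroxy group, gives a number 7 percentage points higher from compound 3 to compound 4 (within the scatter) in this assay. Within the data shown here, the earlier compounds offered only one number, so no step could be read; this pair gives the first, and it shows that the two halogens cannot be told apart at this position in this read-out. Nothing measured here bears on the reason for this result.

From the compounds shown here alone, compound 1 and compound 2 carry no number, so steps involving them cannot be read, and how far the hydroxy and amino groups at this position really stand from the two halogens remains unknown. Also open, going by these compounds, is whether a bromo, methyl or methoxy group on the same carbon would read like chloro and fluoro, and whether any change here could lift the inhibition beyond the scatter, since these two compounds show only that one halogen can replace the other at a single tested concentration.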